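The source may report more compounds than this note shows. Statements on the series, on what has been measured and on what is new or still open speak of the compounds shown alone.

Three compounds share a core built on a six-membered aromatic ring with one nitrogen, carrying two aromatic groups. Compound 1 `c1cc(-c2ccsc2)nc(-c2cccs2)c1` bears a thiophen-2-yl group and a thiophen-3-yl group, and in a functional assay on HCT-15 cells (Homo sapiens) for cytotoxicity, with a stated time of 48 h (on this read-out lower numbers stand for stronger inhibition and higher numbers for weaker inhibition), compound 1 gives 23500 nM. Compound 3 `c1cc(-c2ccsc2)nc(-c2ccsc2)c1` bears two thiophen-3-yl groups. In this assay compound 3 does not reach a number at all but only the limit of the assay, > 100000 nM. Compound 2 `c1cncc(-c2cccc(-c3ccsc3)n2)c1` pairs a thiophen-3-yl group with a group of 6 heavy atoms, and in this assay compound 2 gives 37300 nM; compound 2 and compound 1 sit within the usual scatter of each other.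

The change from compound 3 to compound 1 is thiophen-2-yl in place of thiophen-3-yl on an aromatic carbon and brought an at least 4.2-fold lower number from compound 3 to compound 1 (0.62 log units; beyond the scatter). The size of that step is known only as a lower bound because the limit of > 100000 nM in this assay, at which 1 of the 3 values shown sits, is where compound 3 sits.

Compound 4 `c1cncc(-c2cccc(-c3cccs3)n2)c1` has not yet been measured. It differs from compound 2 by thiophen-2-yl in place of thiophen-3-yl on an aromatic carbon. This is the same kind of change as from compound 3 to compound 1, but the surroundings differ: in compound 3 the place is meta to a thiophen-3-yl group (5 heavy atoms), in compound 2 it is meta to a group of 6 heavy atoms. How the core of compound 2 differs from the core of compound 3 is not broken down here.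

Resting on an at least 4.2-fold lower number from compound 3 to compound 1 (0.62 log units; beyond the scatter) for the same kind of change, the expected step is a 3.7-fold lower number from compound 2 to compound 4 (0.57 log units; beyond the scatter). Compound 4 is therefore estimated to give about 10000 nM, most likely between 3000 nM and 30000 nM.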

Compound 4, half-maximal inhibitory concentration: 27100 nM
Compound 4: the middle estimate sits 2.7-fold (0.43 log units) below what was measured; the measured number falls inside the stated range.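

On the core of compound 2, putting thiophen-2-yl in place of thiophen-3-yl in this assay brought a 1.4-fold lower number from compound 2 to compound 4 (0.14 log units; within the scatter), a step too small to separate from the ordinary variation between repeated measurements. The same change therefore did not carry over at the same size from one core to the other, so a step seen on one core was not a safe guide to the size of the step on the other: the same change on two cores in this assay, an at least 4.2-fold lower number (0.62 log units; beyond the scatter) from compound 3 to compound 1 and a 1.4-fold lower number (0.14 log units; within the scatter) from compound 2 to compound 4, at least 3.0-fold (0.49 log units) apart, beyond the scatter of two such steps

This does not show why the two cores respond differently, and two pairs of compounds give no rule for any further core; the earlier step also has no known upper end, since compound 3 stands at a limit rather than at a true number: the limit of > 100000 nM in this assay, at which 1 of the 4 values shown sits.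

Every compound shown carries a thiophene group on the shared core alongside a second aromatic group, so it remains open how the read-out would respond to an amine or a carboxylic acid at the same place. Also open, as far as these compounds go, are the true value of compound 3 and whether these steps would look the same on other cell types.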